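The compounds below may be only part of what the source reports. "The series", "measured", "known", "first", "only" and "open" are said of these compounds alone.

Measured compounds:
compound 1, `O=C(NCc1ccccc1)c1csc(-c2c[nH]c3ccccc23)n1`; in a functional assay on MDA-MB-231 cells (Homo sapiens) for cytotoxicity, read by MTT assay, with a stated time of 48 h, in the presence of a further agent that is not named here (a lower number here means a stronger inhibitor, a higher number a weaker inhibitor), compound 1 gives > 100000 nM, a limit of the assay and not a number.
compound 2, `COc1ccc(NC(=O)c2csc(-c3cn(Cc4ccc(Cl)cc4)c4ccccc34)n2)cc1`; in this assay compound 2 gives > 100000 nM, likewise a limit.

Compound 2 therefore stands at the limit, not at a measured number, and the other measured value sits at the same limit (the limit of > 100000 nM in this assay, at which 2 of the 2 values shown sit). Within the data shown here, no step between measured compounds exists in this set, so nothing shows how far any change moves the read-out.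

Compound 3, `O=C(Nc1ccccc1)c1csc(-c2cn(Cc3ccc(Cl)cc3)c3ccccc23)n1`, differs from compound 2 by hydrogen in place of methoxy on an aromatic carbon, para to a large group. With both measured values at the limit, no direction or size of step in this assay can be taken from the data; a step within the scatter, or none, is the working assumption, and a value reported only as a limit is the likeliest outcome.

Compound 3 is expected at 150000 nM, within 40000 nM to 600000 nM. The expected step is a step that the limit leaves unreadable from compound 2 to compound 3.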

Compound 3, half-maximal inhibitory concentration: > 100000 nM
Compound 3 was reported as a limit (the forecaster's own chance of this, stated with the estimate: 85%); the middle value lies beyond the limit too.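

Among these compounds, no step from compound 2 to compound 3 can be read in this assay, as the values of both compounds are limits of the assay and not numbers: the limit of > 100000 nM in this assay, at which 3 of the 3 values shown sit. The compounds shown leave open which structural change, if any, would give a measured number in this assay.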